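The compounds below may be only part of what the source reports. "The series", "measured", "known", "first", "only" and "open" are said of these compounds alone.

Working notes on the series. Compound 1 `COc1ccc(C2N=C(SCc3cccc(Cl)c3)NC(C)=C2C(=O)Nc2ccc(F)cc2)cc1OC` and compound 2 `COc1ccc(C2N=C(SCc3ccc(Cl)cc3)NC(C)=C2C(=O)Nc2ccc(F)cc2)cc1OC` share one core; compound 3 `CC1=C(C(=O)Nc2ccc([N+](=O)[O-])cc2)C(c2ccc(Br)cc2)N=C(SCc2cccc(Cl)c2)N1` and compound 4 `CC1=C(C(=O)Nc2ccc([N+](=O)[O-])cc2)C(c2ccc(Br)cc2)N=C(SCc2ccc(Cl)cc2)N1` share another, and the difference between the two cores is not broken down here. In a functional assay on the whole organism (artery, strain albino) with Rattus norvegicus as the target, with a stated time of 120 min, at a dose of 10 mg/kg by the oral route (on this read-out higher numbers stand for more inhibition at the one dose given (going by the name of the read-out) and lower numbers for less inhibition), compound 1 gives 10.8%, and compound 2 gives 15.5%. The change between them, (4-chlorophenyl in place of 3-chlorophenyl on a saturated chain carbon bound to a sulfur), made a step of a number 4.7 percentage points higher from compound 1 to compound 2 (within the scatter). In this assay compound 3 gives 6.7%, which lies within the scatter of both others. Compound 4 carries the same change on the second core, (4-chlorophenyl in place of 3-chlorophenyl on a saturated chain carbon bound to a sulfur). Resting on the single measured instance of this change, a number 4.7 percentage points higher from compound 1 to compound 2 (within the scatter), the expected step is a number 4.3 percentage points higher from compound 3 to compound 4 (within the scatter), with the caution that one instance is a thin basis. Compound 4 is therefore estimated at 11% in this assay, with a range of 3% to 20%.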

Compound 4, a percentage reported as inhibition, in the whole organism at one dose (the size of the read-out at that dose, not a potency): 13.9%
Compound 4: the middle estimate sits 2.9 percentage points below what was measured, and the stated range covers the measured number.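

In this assay, the change from 3-chlorophenyl to 4-chlorophenyl on the second core gives a number 7.2 percentage points higher from compound 3 to compound 4 (within the scatter), and the steps on the two cores do not differ: the same change on two cores in this assay, a number 4.7 percentage points higher (within the scatter) from compound 1 to compound 2 and a number 7.2 percentage points higher (within the scatter) from compound 3 to compound 4, 2.5 percentage points apart, within the scatter of two such steps. The change therefore carries across these two cores with a step of similar size. However, neither step exceeds the scatter, so the data do not show that the change itself shifts the read-out, and two pairs establish no rule for any other core in the series.

Open, as far as these compounds go, is how the read-out responds when an amine, a carboxylic acid or an unsubstituted phenyl takes the place of the chlorophenyl on the saturated chain carbon bound to a sulfur. Also open, from the compounds shown here alone, is the effect of a longer chain on that sulfur.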